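Adding one methoxy to compound 2: working notes

This account rests on a few compounds, and the source may have more. Where it says the series, first, only, none or still open, it means among the compounds named here.

Measured in an ADME assay on BJ cells (Homo sapiens) for cytotoxicity, read by MTT assay, with a stated time of 72 h; on this read-out lower numbers stand for stronger inhibition and higher numbers for weaker inhibition:
- compound 1 `COc1cc(OC)c(OC)cc1CNc1ncnc2c1ncn2C1CCCCO1`: > 100000 nM
- compound 2 `COc1ccc(CNc2ncnc3c2ncn3C2CCCO2)c(OC)c1`: > 100000 nM

Both entries are limits of the assay and not numbers. Compound 2 stands at > 100000 nM, which is a limit. Compound 1 stands at > 100000 nM, which is also a limit. For the measured compounds named here, the series so far offers only one observation: the limit of > 100000 nM in this assay, at which 2 of the 2 values shown sit.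

Compound 3 `COc1cc(OC)c(OC)cc1CNc1ncnc2c1ncn2C1CCCO1` departs from compound 2 by a single change, methoxy in place of hydrogen on an aromatic carbon. Going by the values given here, no step between measured compounds is available, so the effect of such a change in this assay has not been measured directly. Among the compounds with values here, no step beyond the usual scatter is expected in either direction, because the limit of > 100000 nM in this assay, at which 2 of the 2 values shown sit, is the only guide. The expected step of a number no higher from compound 2 to compound 3 (the limit leaves the size open) is correspondingly small. For compound 3 the estimated value is 100000 nM, with an expected range from 50000 nM to 200000 nM. A report as a limit, rather than as a number, is the expected outcome.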

Compound 3, half-maximal inhibitory concentration: > 100000 nM
Compound 3 ended at the assay's limit (the forecaster's own chance of this, stated with the estimate: 85%); the middle value lies on the limit itself.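

Neither the step from compound 2 to compound 3 nor the step from compound 1 to compound 3 can be read: the limit of > 100000 nM in this assay, at which 3 of the 3 values shown sit.

The compounds shown leave open whether methoxy in place of hydrogen on an aromatic carbon, or oxolan-2-yl in place of oxan-2-yl on an aromatic nitrogen, has any effect on the read-out.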